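The source may report more compounds than this note shows. Statements on the series, on what has been measured and on what is new or still open speak of the compounds shown alone.

Measured compounds:
- compound 1, `CC(C)COc1cccc(-c2ccc(C(=O)N(Cc3cccc(OCCCCCC(=O)O)c3)C(C)C)cc2)c1`: > 26000 nM
- compound 2, `CCCNCc1ccccc1OCCCCCC(=O)OCC`: > 26000 nM

The read-out is an ADME assay on Raji cells (Homo sapiens) for cytotoxicity, read by CellTiter-Glo and resazurin assay, with a stated time of 72 h; a lower number here means that less compound is needed, a higher number that more compound is needed for the effect. Compound 1 gives > 26000 nM, which is a limit of the assay and not a number. Compound 2 gives > 26000 nM, again a limit and not a number. Compound 2 therefore stands nowhere that can be ranked: both values shown sit at the limit of > 26000 nM in this assay, at which 2 of the 2 values shown sit, and no order between compound 2 and compound 1 can be drawn from them. Nothing in the series yet ties a single structural change to a measured shift in this assay.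

The next compound, compound 3, `CCOC(=O)CCCCCOc1ccccc1C=O`, differs from compound 2 in one place: formyl in place of (propylamino)methyl on an aromatic carbon. In words, formyl in place of (propylamino)methyl on an aromatic carbon. For the measured compounds named here, no measured step between compounds differing in one place is available, so the size of this step cannot be read from the data; the expectation is for no step beyond the scatter, with the value again likely to come back as a limit. Compound 3 is expected to give 40000 nM, in a range from 15000 nM to 150000 nM. The step this estimate implies, a step that the limit leaves unreadable from compound 2 to compound 3, is expected to stay within the usual scatter.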

Compound 3, half-maximal effective concentration: > 26000 nM
Compound 3: only a limit was reported (the forecaster's own chance of this, stated with the estimate: 85%); the middle value is on the limit's open side.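

Compound 3 returns only a limit and not a number, like compound 2, so no step can be read between compound 2 and compound 3, because the series rests on one limit: the limit of > 26000 nM in this assay, at which 3 of the 3 values shown sit. The compounds shown leave open whether any change in one place would give a measurable value in this assay.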